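Replacing the group on the sulfonyl sulfur of compound 2

The source may report more compounds than this note shows. Statements on the series, on what has been measured and on what is new or still open speak of the compounds shown alone.

Compound 1 `CC(C)n1cc(S(=O)(=O)c2ccc(CNC(=O)N3Cc4ccncc4C3)cc2)cn1`: 11 nM
Compound 2 `CCC(=O)N1CCC(S(=O)(=O)c2ccc(CNC(=O)N3Cc4ccncc4C3)cc2)CC1`: 54 nM

Both compounds were measured in a functional assay on A2780 cells (Homo sapiens) for cytotoxicity, read by sulforhodamine B assay, with a stated time of 72 h; on this read-out higher numbers stand for weaker inhibition and lower numbers for stronger inhibition. Of the two, compound 2 has the higher number, 54 nM, so it is the weaker inhibitor. Compound 3 `O=C(NCc1ccc(S(=O)(=O)N2CCC[C@H](O)C2)cc1)N1Cc2ccncc2C1` has not yet been measured. It carries 3-hydroxypiperidin-1-yl in place of 1-propanoylpiperidin-4-yl on a sulfonyl sulfur.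

Within the data shown here, only one measured step bears on this change, since it involves the same place: a 4.9-fold higher number from compound 1 to compound 2 (0.69 log units; beyond the scatter). That modest step shows that swapping this group can move the number beyond the scatter, but a single step gives no direction for the new group. Among the measured compounds shown here, a change no larger than that step is therefore expected, quite possibly within the scatter.

The expected change is a 1.4-fold lower number from compound 2 to compound 3 (0.13 log units; within the scatter). Compound 3 is estimated at 40 nM, with an expected range from 12 nM to 130 nM.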

Compound 3, half-maximal inhibitory concentration: 150 nM
Compound 3: middle estimate off by 3.8-fold (0.57 log units), on the low side; the measured number lies above the stated range.
By their numbers in this assay, from the lowest: compound 1; then compound 2; then compound 3.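

In this assay, the change to 3-hydroxypiperidin-1-yl gives a 2.8-fold higher number from compound 2 to compound 3 (0.44 log units; beyond the scatter), and the widest span seen at this place is a 14-fold higher number from compound 1 to compound 3 (1.13 log units; beyond the scatter). The group on the sulfonyl sulfur can therefore move the number a long way, and all three groups now stand apart beyond the scatter, with 3-hydroxypiperidin-1-yl giving the weakest inhibition. No available measurement explains why this group gives a higher number.

Compared with 1-propanoylpiperidin-4-yl, the entering group differs in several ways at once: it has fewer heavy atoms, a hydrogen-bond donor and a defined stereocentre, so the compounds shown cannot say which difference matters. A plain piperidin-1-yl group, or a 3-methoxypiperidin-1-yl group, would help show what the hydroxyl contributes, and the opposite stereoisomer of compound 3 would test the stereocentre.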